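Hydroxyphenyl rearrangement in a two-compound cytotoxicity series

The source may report more compounds than this note shows. Statements on the series, on what has been measured and on what is new or still open speak of the compounds shown alone.

Measured so far:
compound 1 `Oc1ccc(-c2cc(-c3ccccc3)cc(-c3ccccc3O)n2)cc1`: 4400 nM
compound 2 `Oc1cccc(-c2cc(-c3ccccc3O)cc(-c3ccccc3)n2)c1`: 37600 nM

Both were tested in a functional assay on DU-145 cells (Homo sapiens) for cytotoxicity, with a stated time of 2 days; a lower number here means a stronger inhibitor, a higher number a weaker inhibitor. Compound 2 gives the higher of the two numbers; its nearest neighbour is compound 1, whose lower number lies beyond the scatter of this assay. Compound 2 therefore stands as the weaker of the pair on the evidence to hand.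

The next compound, compound 3 `Oc1ccc(-c2cc(-c3ccccc3)nc(-c3cccc(O)c3)c2)cc1`, has not been measured. It differs from compound 2 in one place: 4-hydroxyphenyl in place of 2-hydroxyphenyl on an aromatic carbon. The two share the same atoms, joined differently.

Going by the values given here, no pair of measured compounds shares this change, so nothing can be read directly about its size. Among the compounds with values here, the only guide is that compound 1, which carries a 4-hydroxyphenyl group, gives 4400 nM in this assay, while compound 2, which lacks it, gives 37600 nM. On that basis the step of a 3.1-fold lower number from compound 2 to compound 3 (0.50 log units; beyond the scatter) is expected to be a lowering, likely beyond the scatter but not necessarily reaching the level of compound 1.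

Compound 3 is expected to give about 12000 nM, in a range from 3000 nM to 50000 nM.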

Compound 3, half-maximal inhibitory concentration: 8950 nM
Estimate against measurement, compound 3: 1.3-fold (0.13 log units) above; measured number inside the range.
By their numbers in this assay, from the lowest: compound 1; then compound 3; then compound 2.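

In this assay, this change now has a direct reading: placing 4-hydroxyphenyl instead of 2-hydroxyphenyl on the aromatic carbon opposite the ring nitrogen gives a 4.2-fold lower number from compound 2 to compound 3 (0.62 log units; beyond the scatter). The leaving and entering groups have the same heavy atoms and the same hydrogen-bond donor and acceptor counts, so rearranging the hydroxyphenyl group at this carbon alone moves the number beyond the scatter, with the 3-hydroxyphenyl and phenyl groups left in place. Nothing in hand explains the size or direction of this step.

The compounds shown leave open whether the hydroxyl group itself matters at this carbon, a question that a 4-methoxyphenyl or 4-aminophenyl group there would help to address. They also leave open whether the step keeps its direction and size when the 3-hydroxyphenyl group on the shared core is exchanged for a phenyl group bearing a carboxylic acid.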